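Swapping Methyl for Nitro on the Shared Core

The source may report more compounds than this note shows. Statements on the series, on what has been measured and on what is new or still open speak of the compounds shown alone.

Compound 1 `Cc1ccc2[nH]c(C(=O)O)c(CCC(=O)O)c2c1`: > 1000000 nM
Compound 2 `CCOC(=O)/C(CCCC(=O)O)=N\Nc1ccc(Cl)cc1`: 20000 nM

Of the compounds shown here, two have been tested in an assay on isolated protein for inhibition of kynurenine--oxoglutarate transaminase 1 (Homo sapiens), read by HPLC, with a stated time of 20 min; a lower number here means a stronger inhibitor, a higher number a weaker inhibitor. Compound 1 gives > 1000000 nM, which is a limit of the assay rather than a measured number (the limit of > 1000000 nM in this assay, at which 1 of the 2 values shown sits). Among the measured compounds shown here, compound 2 gives 20000 nM in this assay; it is built on a different framework, and no single-point relation to compound 1 is available, so the two values show only that compound 2 yields a measured number where compound 1 does not.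

Compound 3 `O=C(O)CCc1c(C(=O)O)[nH]c2ccc([N+](=O)[O-])cc12` differs from compound 1 in one place: nitro in place of methyl on an aromatic carbon, a nitro in place of methyl on an aromatic carbon. For the measured compounds named here, no measured pair differing in one place exists here, so there is no direct guide to what this exchange does in this assay. Given that compound 1 sits at a limit (the limit of > 1000000 nM in this assay, at which 1 of the 2 values shown sits), the step from compound 1 to compound 3 is expected to be small or absent, at most a modest shift toward stronger inhibition, and is written as an at least 1.6-fold lower number from compound 1 to compound 3 (0.22 log units; that floor lies within the scatter). Compound 3 is therefore estimated to give 600000 nM, with a plausible range from 60000 nM to 6000000 nM, and a real chance that only a limit is reported again.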

Compound 3, half-maximal inhibitory concentration: 666000 nM
Compound 3: the middle estimate sits 1.1-fold (0.05 log units) below what was measured; the measured number falls inside the stated range.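

With nitro in place of methyl on the aromatic carbon, the shared core now gives a real reading in this assay, so compound 3 supplies a measured anchor on this framework that compound 1 could not provide. The change reads as an at least 1.5-fold lower number from compound 1 to compound 3 (0.17 log units; that floor lies within the scatter), which means that the data set only a floor on the step and cannot show that the exchange makes a real difference. The true size of the step stays hidden because one end of it is a limit and not a number: the limit of > 1000000 nM in this assay, at which 1 of the 3 values shown sits.

The compounds shown leave open how far compound 1 actually lies from compound 3, and so whether nitro at this position does anything beyond the usual scatter. They also leave open how an amine, a methoxy group or a chlorine on the same aromatic carbon would read in this assay, and whether a longer chain in place of the acid side chain of the shared core would matter more than any change at this position.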